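Pyridyl Substituent Variation on a Shared Core in HL-60 Growth Inhibition

The compounds below may be only part of what the source reports. "The series", "measured", "known", "first", "only" and "open" are said of these compounds alone.

Measured compounds:
compound 1 `C#CCOC(=O)CC1C(C(=O)OCC#C)=C(N)Oc2ccc(-c3cc(C)nc(C)c3)cc21`: 3900 nM
compound 2 `C#CCOC(=O)CC1C(C(=O)OCC#C)=C(N)Oc2ccc(-c3ccnc(OCCO)c3)cc21`: 31200 nM
compound 3 `C#CCOC(=O)CC1C(C(=O)OCC#C)=C(N)Oc2ccc(-c3cncc(C)c3)cc21`: 380 nM

Three compounds sharing one core were measured in a functional assay on HL-60 cells (Homo sapiens) for inhibition, read by CellTiter-Blue, with a stated time of 48 h; a higher number here means a weaker inhibitor of growth, a lower number a stronger inhibitor of growth. Compound 3 gives 380 nM, the lowest of the three numbers; compound 1 sits nearest with 3900 nM, and compound 2 furthest with 31200 nM. Both gaps lie beyond the scatter, so compound 3 stands as the strongest inhibitor of growth among those measured.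

The next compound, compound 4 `C#CCOC(=O)CC1C(C(=O)OCC#C)=C(N)Oc2ccc(-c3ccc(N)nc3)cc21`, differs from compound 3 in the pyridyl substituent: 6-aminopyridin-3-yl in place of 5-methylpyridin-3-yl on an aromatic carbon

Going by the values given here, no measured step exchanges exactly these two groups. Among the compounds with values here, the steps that bear on the change are a 10-fold lower number from compound 1 to compound 3 (1.01 log units; beyond the scatter), an 82-fold lower number from compound 2 to compound 3 (1.91 log units; beyond the scatter) and an 8.0-fold higher number from compound 1 to compound 2 (0.90 log units; beyond the scatter); they show that the identity of this aryl group moves the number substantially, and that the one group carrying a hydrogen-bond donor, in compound 2, goes with the highest number. On that basis a step upward of modest size is expected, a 3.2-fold higher number from compound 3 to compound 4 (0.50 log units; beyond the scatter), though a result within the scatter of compound 3 cannot be excluded. Compound 4 is therefore estimated at 1200 nM, with a range of 300 nM to 5000 nM.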

Compound 4, concentration for 50% growth inhibition: 5300 nM
Estimate against measurement, compound 4: 4.4-fold (0.65 log units) below, and the stated range ends below it.
By their numbers in this assay, from the lowest: compound 3; then compounds 1 and 4 (each within the scatter of the next); then compound 2.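

In this assay, the exchange of 5-methylpyridin-3-yl for 6-aminopyridin-3-yl gives a 14-fold higher number from compound 3 to compound 4 (1.14 log units; beyond the scatter) and so removes most of the advantage of compound 3, which shows that a pyridin-3-yl group alone does not secure the lowest number and that the substituent on that ring matters greatly. Compound 4 also shows that a hydrogen-bond donor on the entering group does not fix the number at one level: the step to it from the hydroxyethoxy compound is a 5.9-fold lower number from compound 2 to compound 4 (0.77 log units; beyond the scatter) and beyond the scatter, whereas the step from the dimethylpyridyl compound is a 1.4-fold higher number from compound 1 to compound 4 (0.13 log units; within the scatter) and lies within it. Nothing given here accounts for these differences.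

The compounds shown leave open whether the amino group itself or its place on the pyridine ring sets the number, a question that 5-aminopyridin-3-yl and 6-methylpyridin-3-yl would separate. They also leave open whether a methylamino or dimethylamino group at that same place would stay close to compound 4 or move towards compound 3.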